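Acetyl for methyl on a shared thiocarbamate core

The compounds below may be only part of what the source reports. "The series", "measured", "known", "first", "only" and "open" are said of these compounds alone.

Three thiocarbamates built on one core have been tested in an ADME assay on MT4 cells (Homo sapiens) for cytotoxicity, read by MTT assay; on this read-out lower numbers stand for higher toxicity in this test and higher numbers for lower toxicity in this test. Compound 1 `Cc1ccccc1NC(=S)OCCc1ccccn1` gives > 100000 nM, which is a limit of the assay rather than a number. Compound 2 `S=C(Nc1ccccc1Cl)OCCc1ccccn1` likewise gives > 100000 nM, again a limit. The step that the two limits leave unreadable from compound 1 to compound 2 therefore cannot be read, and the limit of > 100000 nM in this assay, at which 2 of the 3 values shown sit, marks where both of these values sit. Among the measured compounds shown here, compound 3 `Cc1ccc(NC(=S)OCCc2ccccn2)cc1` is the one compound with a number in this assay, 75000 nM. It stands alone in that respect, and no ordering among the three compounds can be drawn from what is shown.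

Compound 4 `CC(=O)c1ccc(NC(=S)OCCc2ccccn2)cc1` differs from compound 3 in one place: acetyl in place of methyl on an aromatic carbon. For the measured compounds named here, no measured step involves an acetyl group, and the single recorded step, from a methyl to a chloro substituent, is unreadable with both of its ends at a limit. Going by the values given here, nothing among the measured compounds bears directly on this change, so the expectation in this assay is a step of no more than the scatter, in no firm direction. On that basis the expected step of a 1.2-fold higher number from compound 3 to compound 4 (0.08 log units; within the scatter) is small. Compound 4 is estimated at 90000 nM, within a range from 35000 nM to 250000 nM, with a fair chance that only a limit is reported.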

Compound 4, half-maximal cytotoxic concentration: >= 100000 nM
Compound 4 gave a limit, no number; the forecaster's own chance of this, stated with the estimate: 50%; middle value at least 1.1-fold (0.04 log units) away from the limit.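

Acetyl in place of methyl on this aromatic carbon, para to a large group, gives an at least 1.3-fold higher number from compound 3 to compound 4 (0.12 log units; that floor lies within the scatter) in this assay, the first step in the series with a readable direction and a floor. On these data alone, that floor lies within the scatter, so the step does not establish a real difference between the two compounds, and its true size stays unknown. Compound 4 reports a limit and not a number: the limit of >= 100000 nM in this assay, at which 1 of the 4 values shown sits.

As far as these compounds go, only methyl and acetyl stand at this aromatic carbon in the compounds that can be compared here, so it remains open whether an amine, a carboxylic acid or a longer chain in the same place would move the number in this assay beyond the scatter. Among the compounds shown here, it is also open whether acetyl in place of methyl would read the same way elsewhere on the aromatic ring, and compound 3 remains the only compound of the four with a number to measure any such change against.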